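Tert-butyl for nitro on the aryl of compound 2

A few compounds are considered here, and "the series" means these few. Any claim that something is new, unique, unknown or untested is made for them only; others in the source may bear on it.

Measured so far in a functional assay on MT4 cells (Homo sapiens) for antiproliferative activity, read by MTT assay, with a stated time of 96 h; a lower number here means a stronger inhibitor, a higher number a weaker inhibitor:
- compound 1 `O=C1NNC(=O)C2(CSC3=C2C(=O)c2ncccc2C3=O)N1`: 550 nM; 500 nM; 550 nM (3 entries)
- compound 2 `O=C1C2=C(C(=O)c3ncccc31)C1(CS2)NC(=O)N(c2ccc([N+](=O)[O-])cc2)C1=O`: 8 nM
- compound 3 `O=C1NN(c2ccc([N+](=O)[O-])cc2)C(=O)C2(CSC3=C2C(=O)c2ncccc2C3=O)N1`: 5 nM

Compound 2 carries the 4-nitrophenyl on the urea-type nitrogen of the shared core. In this assay compound 2 gives 8 nM, the higher of the two single numbers, with compound 3 at 5 nM as the nearest value; the gap between the two lies within the scatter, so no order is read from it. Compound 1, lacking the aryl group, stands far weaker, and its repeat entries the several entries of compound 1 in this assay, 550 nM; 500 nM; 550 nM (3 entries) show how tightly the assay reproduces.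

The next compound, compound 4 `CC(C)(C)c1ccc(N2C(=O)NC3(CSC4=C3C(=O)c3ncccc3C4=O)C2=O)cc1`, differs from compound 2 in one place only: tert-butyl in place of nitro on an aromatic carbon. For the measured compounds named here, no measured pair isolates the contribution of the nitro group itself, so whether the gain seen between compound 1 and compound 2 rests on the aryl ring as such or on the nitro group cannot be split from the numbers at hand.

For compound 4 a weakening beyond the scatter is expected, a 5.0-fold higher number from compound 2 to compound 4 (0.70 log units; beyond the scatter), with a wide allowance given that the aryl ring is retained. Compound 4 is therefore estimated at 40 nM, with a range of 8 nM to 250 nM.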

Compound 4, half-maximal inhibitory concentration: 200 nM
Compound 4: the middle estimate sits 5.0-fold (0.70 log units) below what was measured; the range from low to high includes it.
By their numbers in this assay, from the lowest: compounds 3 and 2 (each within the scatter of the next); then compound 4.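

For the compounds shown here, this pair is the first to differ in one place only, and it shows that the group on the aryl ring strongly affects the read-out in this assay: going from 4-nitrophenyl to 4-(tert-butyl)phenyl gives a 25-fold higher number from compound 2 to compound 4 (1.40 log units; beyond the scatter). The aryl ring is retained across this step, so the ring alone does not secure a number at the level of compound 2, at 8 nM, and the group on that ring carries much of the outcome. The step is far wider than the spread among repeat readings, so it is not a matter of assay reproducibility: the several entries of compound 1 in this assay, 550 nM; 500 nM; 550 nM (3 entries)

With only two groups shown at this position, one pair cannot say which feature of the exchange drives the step. As far as these compounds go, whether an amine, a carboxylic acid, a methoxy group or plain hydrogen on the same aromatic carbon would give a number close to that of compound 2 or compound 4 remains open, as does whether the same exchange on compound 3 would produce a step of similar size.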